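From Cyclopropyl to Ethyl on the Amide Nitrogen

The source may hold more compounds than are shown below. What is called first, only, known or untested is meant among the compounds shown, and "the series" means these compounds.

Compound 1 `COc1cccc(CN(C(=O)c2c[nH]c3nc(-c4cn[nH]c4)ccc23)C2CC2)c1` was tested in an assay on isolated protein for inhibition of Rho-associated protein kinase 1 (Homo sapiens) (on this read-out higher numbers stand for weaker inhibition and lower numbers for stronger inhibition), where compound 1 gives 30 nM. Of the two numbers recorded in this assay, the value for compound 1 is the higher one. The other compound, compound 2 `COc1cccc(CNC(=O)c2cn(-c3ccccc3)c3cc(-c4cn[nH]c4)ccc23)c1`, gives 21 nM in this assay, and the two values lie within the usual scatter of each other, so nothing can be said about an order between them. Going by the values given here, no single-point step between measured compounds is available, so there is no measured precedent for the change that follows.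

Compound 3 `CCN(Cc1cccc(OC)c1)C(=O)c1c[nH]c2nc(-c3cn[nH]c3)ccc12` has not yet been measured. It differs from compound 1 in one place: ethyl in place of cyclopropyl on an amide-type nitrogen. Both groups are small carbon substituents with no donors or acceptors, so no step beyond the scatter is expected in either direction. The step from compound 1 to compound 3 is estimated at a 1.3-fold higher number from compound 1 to compound 3 (0.12 log units; within the scatter) in this assay. In this assay compound 3 is expected to give about 40 nM, with a range from 15 nM to 110 nM.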

Compound 3, half-maximal inhibitory concentration: 76 nM
Compound 3: the middle estimate sits 1.9-fold (0.28 log units) below what was measured; low and high end bracket the measured number.
By their numbers in this assay, from the lowest: compounds 2 and 1 (each within the scatter of the next); then compound 3.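

In this assay, ethyl in place of cyclopropyl on the amide-type nitrogen gives a 2.5-fold higher number from compound 1 to compound 3 (0.40 log units; beyond the scatter), a modest step but one beyond the scatter. Going by these compounds alone, this is the first sign that this nitrogen does not treat small carbon substituents alike: the two groups both carry no hydrogen-bond donors or acceptors and no net charge, yet the number still moves, with only the three-membered ring and one carbon separating them. Nothing available accounts for this step.

A single pair cannot tell whether the ring or the extra carbon matters, and an isopropyl group, which has the same number of carbons as cyclopropyl but no ring, would be the direct way to separate the two; methyl or cyclobutyl on the same nitrogen would show whether the trend continues with size. Going by these compounds, compound 2 differs from compound 1 and compound 3 in more than one place, so it adds nothing on this nitrogen, and how the amide hydrogen itself compares with either group on the core of compound 1 remains open.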